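A few compounds are considered here, and "the series" means these few. Any claim that something is new, unique, unknown or untested is made for them only; others in the source may bear on it.

Among the measured compounds shown here, compound 3 `CN1C(=O)C(c2cccc(Cl)c2)N(C)c2nc(Nc3ccc(S(N)(=O)=O)cc3)ncc21` stands second highest of the three numbers so far in an assay on Sf9 cells for inhibition of serine/threonine-protein kinase 4 (Homo sapiens), read by luminescence and ADP-Glo, with a stated time of 1 h, in the presence of a further agent that is not named here (a lower number here means a stronger inhibitor, a higher number a weaker inhibitor), where compound 3 gives 989 nM. Compound 2 `CN1C(=O)C(c2ccc(F)cc2)N(C)c2nc(Nc3ccc(S(N)(=O)=O)cc3)ncc21`, carrying 4-fluorophenyl on the saturated ring carbon, gives 1770 nM; the step of a 1.8-fold lower number from compound 2 to compound 3 (0.25 log units; within the scatter) is within the scatter, so the two aryl analogues cannot be ordered. Compound 1 `CN1C(=O)C(CC2CC2)N(C)c2nc(Nc3ccc(S(N)(=O)=O)cc3)ncc21`, carrying cyclopropylmethyl at that carbon, gives 211 nM, and both an 8.4-fold higher number from compound 1 to compound 2 (0.92 log units; beyond the scatter) and a 4.7-fold higher number from compound 1 to compound 3 (0.67 log units; beyond the scatter) lie beyond the scatter.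

Compound 4 `CN1C(=O)C(Cc2ccccc2)N(C)c2nc(Nc3ccc(S(N)(=O)=O)cc3)ncc21` differs from compound 3 by benzyl in place of 3-chlorophenyl on a saturated ring carbon. For the measured compounds named here, no measured step exchanges 3-chlorophenyl for benzyl directly. Going by the values given here, the steps that bear on it are a 4.7-fold higher number from compound 1 to compound 3 (0.67 log units; beyond the scatter), showing that a directly attached aryl in place of cyclopropylmethyl weakened inhibition, and a 1.8-fold lower number from compound 2 to compound 3 (0.25 log units; within the scatter), showing that the two aryls were interchangeable. Benzyl is, like cyclopropylmethyl, not an aryl bonded directly to the ring carbon, so a drop of the number toward compound 1 is expected, though not with certainty all the way to 211 nM. The expected step is a 2.5-fold lower number from compound 3 to compound 4 (0.39 log units; beyond the scatter). Compound 4 is estimated at 400 nM, with a range from 150 nM to 1200 nM.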

Compound 4, half-maximal inhibitory concentration: > 10000 nM
Compound 4: a limit, no number; the forecaster's own chance of this, stated with the estimate: 2%; middle value at least 25-fold (1.39 log units) away from the limit.
By their numbers in this assay, from the lowest: compound 1; then compounds 3 and 2 (each within the scatter of the next). At a limit, above all of these: compound 4.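

Compound 4 stands at a limit of the assay, not at a number: the limit of > 10000 nM in this assay, at which 1 of the 4 values shown sits. Among the compounds shown here, the position therefore tolerates less than the earlier compounds showed, since benzyl falls behind both directly attached aryls, with an at least 10-fold higher number from compound 3 to compound 4 (1.00 log units; beyond the scatter) and an at least 5.6-fold higher number from compound 2 to compound 4 (0.75 log units; beyond the scatter), so a chain carbon between the ring carbon and the aromatic ring gives no recovery in this set. The change from cyclopropyl to phenyl on that chain carbon, an at least 47-fold higher number from compound 1 to compound 4 (1.67 log units; beyond the scatter), shows that the chain carbon alone does not preserve the inhibition seen with compound 1, and that the group it carries matters strongly.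

As far as these compounds go, all three steps are lower bounds, so the true size of the loss remains unknown. Also open, from the compounds shown here alone, is whether a plain methyl, a longer alkyl chain or an aminomethyl group at this carbon would match or pass compound 1.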